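Replacing 3-hydroxyphenyl with 4-chlorophenyl on the shared core

The source may report more compounds than this note shows. Statements on the series, on what has been measured and on what is new or still open speak of the compounds shown alone.

Measured compounds:
Compound 1, `CN1CCN(c2nc(-c3ccc(Cl)c(Cl)c3)nc3[nH]cnc23)CC1`: 631 nM
Compound 2, `CN1CCN(c2nc(-c3cc(Cl)ccc3Cl)nc3[nH]cnc23)CC1`: 2510 nM
Compound 3, `CN1CCN(c2nc(-c3cccc(O)c3)nc3[nH]cnc23)CC1`: 158 nM

In an assay on cells for displacement of a labelled ligand from adenosine receptor A1 (Homo sapiens), read by scintillation counting and radioligand binding, with a stated time of 60 min (on this read-out lower numbers stand for stronger inhibition and higher numbers for weaker inhibition), compound 3 gives the lowest of the three numbers. The nearest is compound 1, as seen in the step of a 4.0-fold lower number from compound 1 to compound 3 (0.60 log units; beyond the scatter), and the furthest is compound 2, as seen in the step of a 16-fold lower number from compound 2 to compound 3 (1.20 log units; beyond the scatter). The two dichlorophenyl compounds themselves differ by the step of a 4.0-fold higher number from compound 1 to compound 2 (0.60 log units; beyond the scatter).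

Compound 4, `CN1CCN(c2nc(-c3ccc(Cl)cc3)nc3[nH]cnc23)CC1`, has not been measured in this assay. It differs from compound 3 in one place: 4-chlorophenyl in place of 3-hydroxyphenyl on an aromatic carbon. Within the data shown here, no measured step covers this exact change. Among the measured compounds shown here, the step most closely related is the reverse of the one from compound 1 to compound 3, a 4.0-fold lower number from compound 1 to compound 3 (0.60 log units; beyond the scatter), which shows that the 3-hydroxyphenyl compound 3 gives a lower number than a chlorophenyl compound 1 carrying chlorine in the same para position as compound 4. A modest step upward is therefore expected, a 3.2-fold higher number from compound 3 to compound 4 (0.50 log units; beyond the scatter). For compound 4 in this assay the estimate is 500 nM, with a range from 150 nM to 1600 nM.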

Compound 4, inhibition constant: 398 nM
Compound 4: the middle estimate sits 1.3-fold (0.10 log units) above what was measured; measured number inside the range.
By their numbers in this assay, from the lowest: compound 3; then compounds 4 and 1 (each within the scatter of the next); then compound 2.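

In this assay, the 3-hydroxyphenyl group still gives the lower number against a group with a single chlorine (a 2.5-fold higher number from compound 3 to compound 4 (0.40 log units; beyond the scatter)), so its lead is not confined to the two dichlorophenyl groups. Exchanging 3,4-dichlorophenyl for 4-chlorophenyl gives only a 1.6-fold lower number from compound 1 to compound 4 (0.20 log units; within the scatter) and so separates these two groups by no more than the usual scatter. The 2,5-dichlorophenyl group stands apart from the 4-chlorophenyl group (a 6.3-fold lower number from compound 2 to compound 4 (0.80 log units; beyond the scatter)), which shows that at this aromatic carbon the placing of the chlorines matters more than whether a second chlorine is present, at least among these compounds.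

As far as these compounds go, whether a 3-chlorophenyl, 4-hydroxyphenyl, aminophenyl or carboxyphenyl group on the same carbon would follow the 3-hydroxyphenyl result remains open. Nothing available here explains these differences.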